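The source may hold more compounds than are shown below. What is called first, only, known or untested is meant among the compounds shown, and "the series" means these compounds.

Measured so far in a functional assay on HCC78 cells (Homo sapiens) for antiproliferative activity, read by MTT assay, with a stated time of 48 h; on this read-out higher numbers stand for weaker inhibition and lower numbers for stronger inhibition:
compound 1 `CC(Oc1cccnc1Nc1cnn(C)c1)c1cccc(C(=O)NCc2ccc(Cl)c(C(F)(F)F)c2)c1` gives 48600 nM
compound 2 `Cc1cnc(Nc2ncccc2OC(C)c2cccc(C(=O)NCc3ccc(F)c(Cl)c3)c2)s1` gives 34700 nM
compound 3 `COc1ccc(CNC(=O)c2cccc(C(C)Oc3ccnc(Nc4cnn(C)c4)c3)c2)cc1OC` gives 76600 nM

Among these three numbers compound 3 has the highest. Its gap to compound 1 lies within the usual scatter of repeated measurements, so those two cannot be told apart; its gap to compound 2 lies beyond the scatter, and compound 2 shows the stronger inhibition of that pair. Compound 4 `Cc1ccc(CNC(=O)c2cccc(C(C)Oc3ccnc(Nc4cnn(C)c4)c3)c2)cc1` is not yet measured and differs from compound 3 in one place: 4-methylphenyl in place of 3,4-dimethoxyphenyl on a saturated chain carbon bound to an amide-type nitrogen. Within the data shown here, no measured pair shows this change on its own, so there is no measured step to lean on. With nothing pointing either way, the step expected in this assay is small, a 1.3-fold lower number from compound 3 to compound 4 (0.11 log units; within the scatter), none beyond the scatter. Compound 4 is therefore estimated at 60000 nM, within a range of 25000 nM to 150000 nM.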

Compound 4, half-maximal inhibitory concentration: 8900 nM
The estimate for compound 4 lay 6.7-fold (0.83 log units) above the measured number, and the stated range ends above it.
By their numbers in this assay, from the lowest: compound 4; then compounds 2, 1 and 3 (each within the scatter of the next, the first and the last beyond it).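

In this assay, 4-methylphenyl in place of 3,4-dimethoxyphenyl gives an 8.6-fold lower number from compound 3 to compound 4 (0.93 log units; beyond the scatter), the first step shown at this position. The number therefore responds to the groups carried on this aromatic ring, even though the ring itself stays the same. No measurement shown accounts for the size of this step.

Going by these compounds, it remains open whether removing the two methoxy groups or adding the methyl group carries the step, since both happen in this one change. Also open, on these data alone, is how an amine or a carboxylic acid on this ring would read out.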